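The source may report more compounds than this note shows. Statements on the series, on what has been measured and on what is new or still open speak of the compounds shown alone.

Measured in a functional assay on HepG2 cells (Homo sapiens) for cytotoxicity, read by MTT assay, with a stated time of 24 h (a higher number here means a weaker inhibitor, a lower number a stronger inhibitor), so far:
- compound 1 `O=C1/C(=C/c2ccncc2)CN(S(=O)(=O)c2ccccc2)C/C1=C\c1ccccc1F` gives 5800 nM
- compound 2 `Cc1ccc(S(=O)(=O)N2C/C(=C\c3ccncc3)C(=O)/C(=C/c3ccccc3F)C2)cc1` gives 9700 nM
- compound 3 `O=C1/C(=C/c2ccncc2)CN(S(=O)(=O)c2ccc(F)cc2)C/C1=C\c1ccccc1F` gives 20300 nM

Compound 3 has the highest number of the three, and both steps that reach it are modest: a 3.5-fold higher number from compound 1 to compound 3 (0.54 log units; beyond the scatter) and a 2.1-fold higher number from compound 2 to compound 3 (0.32 log units; beyond the scatter) are the only two on record that end there. The next compound, compound 4 `O=C1/C(=C/c2ccncc2)CN(S(=O)(=O)c2ccc(Cl)cc2)C/C1=C\c1ccccc1F`, differs from compound 3 by chloro in place of fluoro on an aromatic carbon and reads as chloro in place of fluoro on an aromatic carbon, para to a large group.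

The three measured steps all sit at this same place, and the third, a 1.7-fold higher number from compound 1 to compound 2 (0.22 log units; within the scatter), is smaller still. Within the data shown here, no chloro compound has been measured, so these steps alone set the scale. A small step is therefore expected, leaning toward a lower number since compound 3 stands at the top of the set with 20300 nM as its value. The estimated step is a 1.6-fold lower number from compound 3 to compound 4 (0.19 log units; within the scatter). Nothing larger than the steps seen so far is expected. The estimate for compound 4 is 13000 nM, with an expected range from 6500 nM to 25000 nM in this assay.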

Compound 4, half-maximal inhibitory concentration: 5300 nM
For compound 4 the middle estimate is 2.5-fold (0.39 log units) above the measured one, and the stated range ends above it.
By their numbers in this assay, from the lowest: compounds 4, 1 and 2 (each within the scatter of the next); then compound 3.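

In this assay the change from fluoro to chloro, on an aromatic carbon para to a large group, gives a 3.8-fold lower number from compound 3 to compound 4 (0.58 log units; beyond the scatter), so the high number of compound 3 does not extend to the chloro compound. With a 1.1-fold lower number from compound 1 to compound 4 (0.04 log units; within the scatter) and a 1.8-fold lower number from compound 2 to compound 4 (0.26 log units; within the scatter), chloro cannot be told apart from hydrogen or methyl at this place, and among the four compounds only the fluoro of compound 3 stands apart. No evidence at hand bears on what separates fluoro from chloro here.

From the compounds shown here alone, whether bromo, methoxy or an amine at this place would group with compounds 1, 2 and 4 or with compound 3 remains open. Going by these compounds, all four compounds share the rest of the core, so whether the same change gives a similar step on a different core also remains open.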